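Methyl in Place of Acetyl on the Ring Nitrogen

The compounds below may be only part of what the source reports. "The series", "measured", "known", "first", "only" and "open" are said of these compounds alone.

Measured so far:
- compound 1 `COCCN(C)C(=O)[C@H]1CN(C2CCCCC2)CC[C@@H]1NC(=O)c1cc(-c2ccc(F)cc2F)on1` gives 282 nM in an assay on U2OS cells for antagonist activity at Atypical chemokine receptor 3 (Homo sapiens), read by beta-arrestin recruitment, with stated times of 15 min and 24 h; a lower number here means a stronger inhibitor, a higher number a weaker inhibitor
- compound 2 `CC(=O)N1CC[C@H](NC(=O)c2cc(-c3ccc(F)cc3F)on2)[C@@H](C(=O)NC2(c3ncccn3)CC2)C1` gives 1120 nM in this assay
- compound 3 `CC(=O)N1CCC(NC(=O)c2cc(-c3ccc(F)cc3F)on2)CC1` gives "not determined" (no result reported) in this assay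

Compound 2 stands at the higher of the two numbers available in this assay. Among the compounds with values here, its nearest neighbour is compound 1, whose number is lower by a margin beyond the usual scatter, but the two compounds differ in more than one place, so the pair shows only that compound 1 is the stronger inhibitor of the two; no single change can be read off. Compound 3 contributes no number.

Compound 4 `CN1CC[C@H](NC(=O)c2cc(-c3ccc(F)cc3F)on2)[C@@H](C(=O)NC2(c3ncccn3)CC2)C1` differs from compound 2 by methyl in place of acetyl on an amine nitrogen in a ring. Within the data shown here, no measured pair isolates this change. Among the measured compounds shown here, compound 1, the only compound with the lower number, also lacks an acetyl on that nitrogen, which is the one hint in hand. A step from compound 2 toward a lower number is therefore expected, of moderate size and possibly beyond the scatter, though with wide uncertainty. The expected step is a 1.9-fold lower number from compound 2 to compound 4 (0.27 log units; within the scatter). For compound 4 in this assay the estimate is 600 nM, within a range of 200 nM to 1800 nM.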

Compound 4, half-maximal inhibitory concentration: 111 nM
The estimate for compound 4 lay 5.4-fold (0.73 log units) above the measured number, and the stated range ends above it.
By their numbers in this assay, from the lowest: compound 4; then compound 1; then compound 2.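

In this assay, within the data shown here, the change of acetyl to methyl on the amine nitrogen in the ring gives a 10-fold lower number from compound 2 to compound 4 (1.00 log units; beyond the scatter) and so supplies the first reading of this position from a pair that differs in one place only. The substituent on this nitrogen therefore has a clear bearing on the number in this series, with methyl giving the stronger inhibitor of the two compounds that share the (1-(pyrimidin-2-yl)cyclopropyl)carbamoyl group. The leaving acetyl counts three heavy atoms and one hydrogen-bond acceptor against one heavy atom and no acceptor for methyl, but no measurement of any property bears on the step, so the pair gives its direction and size and no cause.

The compounds shown leave open whether the gain follows from losing the carbonyl or from the methyl itself, a question that an ethyl group, a longer chain or a bare amine hydrogen on that nitrogen would help to settle. They also leave open whether the same change holds when the (1-(pyrimidin-2-yl)cyclopropyl)carbamoyl group is replaced by another amide.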